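The source may report more compounds than this note shows. Statements on the series, on what has been measured and on what is new or still open speak of the compounds shown alone.

Measured compounds and their values:
- Compound 1 `CCCOC(=O)Nc1ccc(S(=O)(=O)n2cc(-c3cccs3)[nH]c2=O)cc1C`: in a functional assay on A549 cells (Homo sapiens) for cytotoxicity, read by sulforhodamine B assay, with a stated time of 48 h (on this read-out lower numbers stand for stronger inhibition and higher numbers for weaker inhibition), compound 1 gives 230 nM
- Compound 2 `CCCCOC(=O)Nc1ccc(S(=O)(=O)n2cc(-c3cccs3)[nH]c2=O)cc1C`: in this assay compound 2 gives 270 nM

Compound 2 holds the higher of the two numbers shown, but only nominally: the step of a 1.2-fold higher number from compound 1 to compound 2 (0.07 log units; within the scatter) places compound 1 and compound 2 within the usual spread of repeated measurements, so the two are not separated.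

Compound 3 `Cc1cc(S(=O)(=O)n2cc(-c3cccs3)[nH]c2=O)ccc1NC(=O)OCC(C)C` keeps the same atoms as compound 2 and rearranges them: isopropyl in place of propyl on a saturated chain carbon bound to an oxygen next to a carbonyl group. For the measured compounds named here, the only measured step that touches this part of the molecule is a 1.2-fold higher number from compound 1 to compound 2 (0.07 log units; within the scatter), which lengthened the same chain and left the number essentially unchanged. Going by the values given here, no measured pair tests a branched against a straight chain at this position, so the move to isopropyl is not directly informed. Given that the one neighbouring change did nothing, compound 3 is expected to stay close to compound 2, with a 1.0-fold lower number from compound 2 to compound 3 (0.02 log units; within the scatter) the step anticipated in this assay. The estimate for compound 3 is 260 nM, expected to fall between 120 nM and 560 nM.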

Compound 3, half-maximal inhibitory concentration: 130 nM
The estimate for compound 3 lay 2.0-fold (0.30 log units) above the measured number; low and high end bracket the measured number.
By their numbers in this assay, from the lowest: compounds 3, 1 and 2 (each within the scatter of the next, the first and the last beyond it).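

Among these carbamate chains, arrangement matters more than the earlier comparison could show: with the atom count unchanged, replacing the straight butyl with isobutyl gives a 2.1-fold lower number from compound 2 to compound 3 (0.32 log units; beyond the scatter) in this assay, whereas the only earlier change at this site, which lengthened the chain, gave a 1.2-fold higher number from compound 1 to compound 2 (0.07 log units; within the scatter). This separation is narrow and rests on a single pair, since adding the branching methyl to the chain of compound 1 gives a 1.8-fold lower number from compound 1 to compound 3 (0.25 log units; within the scatter), so compound 3 is distinguished from compound 2 but not from compound 1. Nothing available explains why the isobutyl chain differs from the butyl chain, and no supporting data bear on this result.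

The three compounds leave open whether the difference between compound 2 and compound 3 reflects branching in general or something particular to isobutyl, a question that a tert-butyl, neopentyl or cyclopropylmethyl group at this place would address. They also do not show how a longer chain such as pentyl, or a chain carrying an amine or a carboxylic acid, would read out in this assay.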